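Nitro for hydrogen on the phenoxy ring of compound 3

A few compounds are considered here, and "the series" means these few. Any claim that something is new, unique, unknown or untested is made for them only; others in the source may bear on it.

Measured compounds:
- compound 1, `Cc1cc(Oc2ccc(/C=N/NC(=S)Nc3ccc(Br)cc3)cc2)ccc1Cl`: 7.89
- compound 2, `Fc1ccc(Oc2ccc(/C=N/NC(=S)Nc3ccc(Br)cc3)cc2)cc1`: 5.82
- compound 3, `S=C(N/N=C/c1ccc(Oc2ccccc2)cc1)Nc1ccc(Br)cc1`: 6.38

In a physicochemical assay for lipophilicity, in phosphate buffer, measured as octanol-water partition, with a stated time of 24 h (on this read-out higher numbers stand for higher lipophilicity and lower numbers for lower lipophilicity), compound 1 gives 7.89, compound 2 gives 5.82 and compound 3 gives 6.38. Compound 3 thus stands second highest of the three: compound 2 is nearest, a number 0.56 log units higher from compound 2 to compound 3 (beyond the scatter), and compound 1 is furthest, a number 1.51 log units lower from compound 1 to compound 3 (beyond the scatter).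

Compound 4, `O=[N+]([O-])c1ccc(Oc2ccc(/C=N/NC(=S)Nc3ccc(Br)cc3)cc2)cc1`, differs from compound 3 in one place: nitro in place of hydrogen on an aromatic carbon.

For the measured compounds named here, no measured step exchanges hydrogen for nitro. Going by the values given here, the only step at this aromatic carbon is the one between compound 2 and compound 3, a number 0.56 log units higher from compound 2 to compound 3 (beyond the scatter), a modest change beyond the scatter, and the two larger steps from compound 1, a number 2.07 log units lower from compound 1 to compound 2 (beyond the scatter) and a number 1.51 log units lower from compound 1 to compound 3 (beyond the scatter), concern a different exchange altogether. The step from compound 3 to compound 4 is therefore expected to be modest in this assay, most likely downward, a number 0.38 log units lower from compound 3 to compound 4 (beyond the scatter). Compound 4 is estimated at 6, within 5.3 to 6.7.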

Compound 4, partition coefficient: 5.68
Compound 4: middle estimate off by 0.32 log units, on the high side; the range from low to high includes it.
By their numbers in this assay, from the lowest: compounds 4 and 2 (each within the scatter of the next); then compound 3; then compound 1.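

In this assay, nitro on this aromatic carbon, para to a large group, gives a number 0.70 log units lower from compound 3 to compound 4 (beyond the scatter) and so becomes the second group here, after fluoro, whose compound stands lower than the one with hydrogen. Nitro in place of fluoro gives a number 0.14 log units lower from compound 2 to compound 4 (within the scatter) and the two groups cannot be told apart on this read-out, so at this place the hydrogen compound stands apart from both. Exchanging the whole 4-chloro-3-methylphenyl for 4-nitrophenyl gives a number 2.21 log units lower from compound 1 to compound 4 (beyond the scatter) and this step is large, whereas nothing measured here accounts for the change that nitro brings.

As far as these compounds go, whether an amine or a carboxylic acid on this carbon would also stand lower than hydrogen remains open. Also open, from the compounds shown here alone, is how much of the large steps from compound 1 belongs to its chloro and how much to its methyl.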